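A Diethylamino Swap at the Assay Limit

This account rests on a few compounds, and the source may have more. Where it says the series, first, only, none or still open, it means among the compounds named here.

In a functional assay on HT-29 cells (Homo sapiens) for inhibition (a lower number here means a stronger inhibitor, a higher number a weaker inhibitor), compound 3 `COc1ccc(/C=C/c2ccc3ccccc3c2)cc1N` gives > 5000 nM as its reading, which is a limit and not a number. Compound 1 `COCCOc1cc(/C=C/c2ccc3ccccc3c2)ccc1OC` gives > 5000 nM as its reading, again a limit. Compound 2 `COc1ccc(/C=C/c2ccc3ccccc3c2)cc1F` gives > 5000 nM as its reading, once more a limit.

Compound 4 `CCN(CC)c1cc(/C=C/c2ccc3ccccc3c2)ccc1OC` carries diethylamino in place of amino on an aromatic carbon, ortho to a methoxy group and meta to a large group diethylamino in place of amino on an aromatic carbon while the rest of the structure stays as in compound 3. The measured steps bear on this change, but they are a step that the two limits leave unreadable from compound 1 to compound 2 and a step that the two limits leave unreadable from compound 1 to compound 3 and a step that the two limits leave unreadable from compound 2 to compound 3 so no size carries over from them. Compound 3 shares the limit of > 5000 nM in this assay, at which 3 of the 3 values shown sit, with the other two, so no clear gain is expected for compound 4 in this assay and a reading at that same limit is the likeliest outcome. The estimated change is a step that the limit leaves unreadable from compound 3 to compound 4 and it remains loosely defined. For compound 4 the expected value is 8000 nM within an estimated range of 2500 nM to 25000 nM at best.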

Compound 4, half-maximal inhibitory concentration: > 5000 nM
Compound 4 ended at the assay's limit; the forecaster's own chance of this, stated with the estimate: 85%; the middle value does not contradict the limit.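

In this assay compound 4 gives > 5000 nM as a limit and not a number. No new step can be read between compound 4 and compound 1, compound 2 or compound 3: the limit of > 5000 nM in this assay, at which 4 of the 4 values shown sit. The compounds shown leave open how far these four actually differ in strength.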